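This account rests on a few compounds, and the source may have more. Where it says the series, first, only, none or still open, it means among the compounds named here.

Two compounds from this study have numbers in hand. Compound 1 `CN(Cc1ccc(I)cc1)CC1C[C@H]2CC[C@]1(C)C2(C)C` gives 7940 nM in an assay on HEK293 cells for displacement of a labelled ligand from C-X-C chemokine receptor type 3 (Homo sapiens); a lower number here means a stronger inhibitor, a higher number a weaker inhibitor. Among the compounds with values here, compound 2 `CN(CC1=CC[C@H]2C[C@@H]1C2(C)C)Cc1ccc(Br)cc1` gives 3160 nM in this assay, the lowest of the two numbers, and the only neighbour, compound 1, sits beyond the scatter with its higher value. Within the data shown here, no two measured compounds differ in just one place, so no single-change step is known from the data themselves; what the pair shows is simply that compound 2 carries the stronger binding of the two.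

The next compound, compound 3 `CN(CC1=CC[C@H]2C[C@@H]1C2(C)C)Cc1ccc(-c2ccc(Cl)cc2)cc1`, keeps the core of compound 2 and changes one thing: 4-chlorophenyl in place of bromo on an aromatic carbon. The change sits on an aromatic carbon of a six-membered aromatic ring of carbon only, para to a large group.

Among the measured compounds shown here, with no measured step to lean on, the expectation rests on compound 2 alone, whose 3160 nM is the starting point. Compound 3 is expected to give a lower number, a step of a 3.2-fold lower number from compound 2 to compound 3 (0.50 log units; beyond the scatter), judged as moderate and somewhat beyond the scatter. The estimate for compound 3 is 1000 nM, with a range from 250 nM to 4000 nM.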

Compound 3, inhibition constant: > 316 nM
Compound 3: no number, only a limit (the forecaster's own chance of this, stated with the estimate: 5%); the middle value is on the limit's open side.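

For compound 3, this assay gives only a limit, > 316 nM, and not a number. The step from compound 2 to compound 3 therefore cannot be read. The compounds shown leave open whether 4-chlorophenyl in place of bromo on the aromatic carbon gives a lower number, a higher one, or no change beyond the scatter.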